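The compounds below may be only part of what the source reports. "The series", "measured", "known", "first", "only" and "open" are said of these compounds alone.

Compound 3 `O=C(Nc1ccc(-n2ccc3nc(C(=O)NCc4ccccc4)ccc32)cc1)Nc1cccc(C(F)(F)F)c1` carries a urea on the shared core. In an ADME assay on HS27 cells (Homo sapiens) for cytotoxicity, read by MTT assay (a higher number here means a weaker inhibitor, a lower number a stronger inhibitor), compound 3 gives only a limit, > 10000 nM. Compound 1 `O=C(Nc1ccc(-n2ccc3nc(C(=O)NCc4ccccc4)ccc32)cc1)Nc1cccc(Cl)c1Cl` likewise stops at a limit, > 10000 nM. Compound 2 `NC(=O)c1ccc2c(ccn2-c2ccc(NC(=O)c3cccc(C(F)(F)F)c3)cc2)n1` also gives a limit, > 10000 nM. The step that the two limits leave unreadable from compound 1 to compound 3 is therefore not readable, and the limit of > 10000 nM in this assay, at which 3 of the 3 values shown sit, marks where every value in this series sits. Compound 4 `O=C(Nc1ccc(-n2ccc3nc(C(=O)NCc4ccccc4)ccc32)cc1)c1cccc(C(F)(F)F)c1` differs from compound 3 by 3-(trifluoromethyl)phenyl in place of (3-(trifluoromethyl)phenyl)amino on a carbonyl carbon. Among the measured compounds shown here, no measured step bears directly on this change. Since compound 1, compound 2 and compound 3 all return no number in this assay, the estimated step that the limit leaves unreadable from compound 3 to compound 4 is expected to stay within the scatter. Compound 4 is expected at 20000 nM, with a range of 10000 nM to 60000 nM, most likely again reported only as a limit.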

Compound 4, half-maximal inhibitory concentration: > 10000 nM
Compound 4: no number, only a limit; the forecaster's own chance of this, stated with the estimate: 80%; the middle value does not contradict the limit.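

In this assay compound 4 gives only a limit, > 10000 nM. The steps to compound 4 from compound 1, compound 2 and compound 3 therefore cannot be read. Whether any change on the shared core yields a number remains open: the limit of > 10000 nM in this assay, at which 4 of the 4 values shown sit.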